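From methoxy to fluoro: compound 2 to compound 3

A few compounds are considered here, and "the series" means these few. Any claim that something is new, unique, unknown or untested is made for them only; others in the source may bear on it.

Compound 1 `FC(F)(F)Oc1ccc(-c2nc3cnc(Nc4ccccn4)cc3[nH]2)cc1` gives 60%
Compound 2 `COc1ccc(Nc2cc3[nH]c(-c4cccc(C(F)(F)F)c4)nc3cn2)nc1` gives 26%

In an ADME assay on microsomes from liver (Homo sapiens) for metabolic stability, read by LC-MS, with a stated time of 30 min, tested at 0.1 uM (a higher number here means that more of the compound is left, a lower number that less of the compound is left), compound 2 stands lowest of the two numbers, and compound 1 lies above it beyond the scatter. The step to compound 3 `Fc1ccc(Nc2cc3[nH]c(-c4cccc(C(F)(F)F)c4)nc3cn2)nc1` is fluoro in place of methoxy on an aromatic carbon and amounts to fluoro in place of methoxy on an aromatic carbon, with 5-methoxypyridin-2-yl becoming 5-fluoropyridin-2-yl. Among the measured compounds shown here, no measured pair shows this change alone, and the two measured compounds differ in more than one place. A rise beyond the scatter is still expected, though with little support: compound 2 gives 26% and compound 1 gives 60% in the same read-out. The estimated step is a number 19 percentage points higher from compound 2 to compound 3 (beyond the scatter) in this assay with wide uncertainty. Compound 3 is estimated at 45% with an expected range of 27% to 65% in this read-out.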

Compound 3, percent of the compound remaining: 34%
The estimate for compound 3 lay 11 percentage points above the measured number; measured number inside the range.
By their numbers in this assay, from the lowest: compounds 2 and 3 (each within the scatter of the next); then compound 1.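

In this assay, the first pair differing in one place gives a number 8 percentage points higher from compound 2 to compound 3 (within the scatter), so compound 2 and compound 3 stand within the scatter of each other. At this position, on an aromatic carbon two atoms from the ring nitrogen, fluoro in place of methoxy therefore leaves no readable change in the percent remaining, and this single pair is all that supports the finding. No measurement bears on why this exchange reads as it does.

From the compounds shown here alone, it remains open whether a nitrile, a chloro group, a dimethylamino group or plain hydrogen at this position would read differently with the rest of compound 2 kept. Going by these compounds, compound 1 and compound 2 differ in more than one place, and which difference carries the gap between them also remains open.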